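Swapping the Aryl Group on the Aromatic Nitrogen

This account rests on a few compounds, and the source may have more. Where it says the series, first, only, none or still open, it means among the compounds named here.

Measured so far in a functional assay on PC-12 cells (Rattus norvegicus) for cytotoxicity, read by MTT assay, with stated times of 2 h and 24 h, tested at 10 uM; a higher number here means a stronger effect of the compound at the concentration tested, a lower number a weaker effect:
compound 1, `Oc1cc(C(F)(F)F)ccc1-c1nc(-c2ccccc2O)n(-c2ccc(OC(F)(F)F)cc2)n1`, gives 92.5%
compound 2, `Oc1cc(C(F)(F)F)ccc1-c1nc(-c2ccccc2O)n(-c2ccccc2Cl)n1`, gives 102%
compound 3, `Cc1cc(C)cc(-n2nc(-c3ccc(C(F)(F)F)cc3O)nc2-c2ccccc2O)c1`, gives 105%

All three share one core and differ only in the aryl group on the aromatic nitrogen. Compound 2 sits close to both neighbours: the step of a number 3 percentage points higher from compound 2 to compound 3 (within the scatter) is within the scatter, and the step of a number 9.5 percentage points higher from compound 1 to compound 2 (within the scatter) is within the scatter as well. Among the measured compounds shown here, only the step of a number 12.5 percentage points higher from compound 1 to compound 3 (beyond the scatter) reaches beyond it, and even that is modest.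

Compound 4, `Oc1cc(C(F)(F)F)ccc1-c1nc(-c2ccccc2O)n(-c2cc(F)cc(F)c2)n1`, is the next variant at this position: 3,5-difluorophenyl in place of 2-chlorophenyl on an aromatic nitrogen. The two steps that bear on it, from compound 1 to compound 2 and from compound 2 to compound 3, both changed the aryl group on the aromatic nitrogen and both stayed within the scatter, so no step beyond the scatter is expected in this assay here either. The expected step is a number 2 percentage points lower from compound 2 to compound 4 (within the scatter). Compound 4 is therefore estimated at 100%, with a range from 88% to 112%.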

Compound 4, a percentage reported as activity, at one concentration (the size of the read-out at that concentration, not a potency): 106%
The estimate for compound 4 lay 6 percentage points below the measured number; the measured number falls inside the stated range.
By their numbers in this assay, from the lowest: compounds 1, 2, 3 and 4 (each within the scatter of the next, the first and the last beyond it).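

In this assay the 3,5-difluorophenyl group gives a number 4 percentage points higher from compound 2 to compound 4 (within the scatter) and, against the 3,5-dimethylphenyl group, a number 1 percentage points higher from compound 3 to compound 4 (within the scatter) on the same core. Compound 4 therefore cannot be told apart from compound 2 or compound 3, and two aryl groups that carry different atoms at the same printed positions, fluorine in compound 4 and methyl in compound 3, read alike. Against the 4-(trifluoromethoxy)phenyl group the change gives a number 13.5 percentage points higher from compound 1 to compound 4 (beyond the scatter) as a modest step, so compound 1 now lies beyond the scatter of two of the other compounds, though not of compound 2.

On these data alone, whether an aryl group carrying an amine or a carboxylic acid, or a longer alkyl chain on this nitrogen, would stay level with these compounds remains open. Nothing given here explains why these aryl groups read as they do.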